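Two methoxy groups in place of one

This account rests on a few compounds, and the source may have more. Where it says the series, first, only, none or still open, it means among the compounds named here.

Measured in a functional assay on MCF7 cells (Homo sapiens) for antiproliferative activity, read by sulforhodamine B assay, with a stated time of 48 h; on this read-out lower numbers stand for stronger inhibition of growth and higher numbers for weaker inhibition of growth:
- compound 1, `O=C(NCc1cn(Cc2ccc(C(F)(F)F)cc2)nn1)c1cn(-c2ccccc2)nc1-c1ccc(F)cc1`: 810 nM
- compound 2, `COc1ccc(Cn2cc(CNC(=O)c3cn(-c4ccccc4)nc3-c3ccc(F)cc3)nn2)cc1`: 650 nM

Compound 2 gives 650 nM in this assay, and compound 1 gives 810 nM; the two numbers sit within the usual scatter of each other, so neither can be called the stronger. Going by the values given here, the one measured step, a 1.2-fold lower number from compound 1 to compound 2 (0.10 log units; within the scatter), shows that swapping the group on the outer aromatic ring left the read-out essentially unchanged.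

Compound 3, `COc1cc(Cn2cc(CNC(=O)c3cn(-c4ccccc4)nc3-c3ccc(F)cc3)nn2)cc(OC)c1`, differs from compound 2 in one place: 3,5-dimethoxyphenyl in place of 4-methoxyphenyl on a saturated chain carbon bound to an aromatic nitrogen. Among the compounds with values here, no measured pair covers this particular swap, so the only guide is that the one change made at the same part of the molecule, from compound 1 to compound 2, stayed within the scatter. On that basis no step beyond the scatter is expected in this assay, in either direction. The estimate for compound 3 is therefore 650 nM, with a range from 250 nM to 1700 nM, which corresponds to an expected step of no change at the digits printed from compound 2 to compound 3 (within the scatter).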

Compound 3, concentration for 50% growth inhibition: 2500 nM
Estimate against measurement, compound 3: 3.8-fold (0.59 log units) below, and the stated range ends below it.
By their numbers in this assay, from the lowest: compounds 2 and 1 (each within the scatter of the next); then compound 3.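

Going by these compounds alone, this position is not indifferent to what it carries: in this assay, the change to 3,5-dimethoxyphenyl gives a 3.8-fold higher number from compound 2 to compound 3 (0.59 log units; beyond the scatter) and is the first step in this small set to lie beyond the scatter, whereas the earlier exchange of trifluoromethyl for methoxy did not. Measured against the trifluoromethyl compound, the same group gives a 3.1-fold higher number from compound 1 to compound 3 (0.49 log units; beyond the scatter) and so leaves compound 3 as the weakest growth inhibitor of the three, while compound 1 and compound 2 cannot be told apart. The outer ring therefore tolerates one swap of its substituent but not every one, and no measurement shown explains the difference.

The step from compound 2 to compound 3 adds a methoxy group and also changes where the methoxy groups sit, so the compounds shown cannot say which of these two differences goes with the weaker growth inhibition. Also open, as far as these compounds go, is how this position would respond to quite different groups on the outer ring, such as a hydroxyl, an amine or a carboxylic acid, or to a longer chain linking that ring to the core.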